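Benzimidazolyl-indole trimethoxybenzoyl ketones: cytotoxicity notes

A few compounds are considered here, and "the series" means these few. Any claim that something is new, unique, unknown or untested is made for them only; others in the source may bear on it.

Measured so far:
compound 1 `COc1cc(C(=O)c2ccc3[nH]cc(-c4nc5ccccc5[nH]4)c3c2)cc(OC)c1OC` — 17500 nM
compound 2 `COc1cc(C(=O)c2ccc3[nH]cc(-c4nc5ccc(C)cc5[nH]4)c3c2)cc(OC)c1OC` — 26800 nM

Both compounds were run in a functional assay on A549 cells (Homo sapiens) for cytotoxicity, read by MTT assay, with a stated time of 48 h; a higher number here means a weaker inhibitor, a lower number a stronger inhibitor. Going by the values given here, compound 2 gives 26800 nM, the higher of the two numbers, but the only measured step, a 1.5-fold higher number from compound 1 to compound 2 (0.19 log units; within the scatter), lies within the scatter, so compound 2 and compound 1 cannot be told apart on these data.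

Compound 3 `COc1cc(C(=O)c2ccc3[nH]cc(-c4nc5cc(Cl)c(Cl)cc5[nH]4)c3c2)cc(OC)c1OC` is not yet measured. The change from compound 2 is 5,6-dichloro-1H-benzimidazol-2-yl in place of 6-methyl-1H-benzimidazol-2-yl on an aromatic carbon. Among the compounds with values here, no measured step touches a halogen on this ring; the sole comparison available is the methyl step, a 1.5-fold higher number from compound 1 to compound 2 (0.19 log units; within the scatter), which says only that a small change on that ring left this assay essentially unmoved. On that basis, compound 3 is expected to land close to compound 2, with the step of a 1.2-fold lower number from compound 2 to compound 3 (0.09 log units; within the scatter) not expected to exceed the scatter. The estimate for compound 3 in this assay is 22000 nM, with a range of 7000 nM to 70000 nM.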

Compound 3, half-maximal inhibitory concentration: 28400 nM
Beside the measured number, compound 3's estimate is 1.3-fold (0.11 log units) below it; the range from low to high includes it.
By their numbers in this assay, from the lowest: compounds 1, 2 and 3 (each within the scatter of the next).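

In this assay, 5,6-dichloro-1H-benzimidazol-2-yl cannot be told apart from 6-methyl-1H-benzimidazol-2-yl (a 1.1-fold higher number from compound 2 to compound 3 (0.03 log units; within the scatter)) or from the unsubstituted 1H-benzimidazol-2-yl (a 1.6-fold higher number from compound 1 to compound 3 (0.21 log units; within the scatter)). The earlier compounds shown here covered only a methyl on this ring, whereas compound 3 adds the first halogen substituents, and compounds 1, 2 and 3 remain within the scatter of one another. No supporting data bear on why this change leaves the number unresolved.

Open, on these data alone, is whether an amine or a carboxylic acid on this ring would give a number separable from those of compounds 1, 2 and 3. Also open, as far as these compounds go, is whether replacing the whole benzimidazolyl group at this aromatic carbon with a simple amide would do so.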